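Aryl ether pyrimidines against A549 growth: pyrrolidine to indoline

A few compounds are considered here, and "the series" means these few. Any claim that something is new, unique, unknown or untested is made for them only; others in the source may bear on it.

Measured values in a functional assay on A549 cells (Homo sapiens) for inhibition, read by MTT assay, with a stated time of 72 h; on this read-out lower numbers stand for stronger inhibition and higher numbers for weaker inhibition:
compound 1 `CN(c1ccc(Oc2ncnc3ccsc23)cc1)c1nccc(N2CCCC2)n1`: 6510 nM
compound 2 `CN(c1ccc(Oc2ncnc3sccc23)cc1)c1nccc(N2CCCC2)n1`: 15100 nM

Going by the values given here, compound 2 holds the highest of the two numbers; its only neighbour is compound 1, and the single step in hand is a 2.3-fold higher number from compound 1 to compound 2 (0.37 log units; beyond the scatter), a swap of one bicyclic ether group for another with the pyrrolidinyl end left untouched.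

Compound 3 `CN(c1ccc(Oc2ncnc3sccc23)cc1)c1nccc(N2CCc3ccccc32)n1` differs from compound 2 by 2,3-dihydro-1H-indol-1-yl in place of pyrrolidin-1-yl on an aromatic carbon. Among the compounds with values here, nothing among the measured pairs changes this position, so the one step in hand does not bear on it and gives no direction. Without a relevant comparison the working assumption is that compound 3 stays near compound 2, with a wide allowance either way for a larger group at that site. The expected step is a 1.3-fold lower number from compound 2 to compound 3 (0.10 log units; within the scatter), which amounts to no change beyond the scatter. Compound 3 is estimated at 12000 nM in this assay, with a range from 3000 nM to 45000 nM.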

Compound 3, half-maximal inhibitory concentration: 19600 nM
Compound 3: middle estimate off by 1.6-fold (0.21 log units), on the low side; low and high end bracket the measured number.
By their numbers in this assay, from the lowest: compound 1; then compounds 2 and 3 (each within the scatter of the next).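

In this assay the exchange of pyrrolidin-1-yl for 2,3-dihydro-1H-indol-1-yl, on the aromatic carbon next to the ring nitrogen, gives a 1.3-fold higher number from compound 2 to compound 3 (0.11 log units; within the scatter) and so separates neither compound from the other. Going by these compounds alone, this is the first reading at this position, since the earlier pair varied only the bicyclic ether group and left the pyrrolidin-1-yl end untouched. At this position, then, a group carrying an added six-membered aromatic ring of carbon only gives a number that cannot be told apart from that of the smaller ring, and no supporting measurement bears on this result.

Still open, on these data alone, is whether any other group at this position, such as morpholine, piperazine or an open-chain dimethylamino group, would move the number beyond the scatter. Also open, as far as these compounds go, is whether the step between the two bicyclic ether groups, a 2.3-fold higher number from compound 1 to compound 2 (0.37 log units; beyond the scatter) with pyrrolidin-1-yl in place, keeps its size and direction when 2,3-dihydro-1H-indol-1-yl occupies this position.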